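A few compounds are considered here, and "the series" means these few. Any claim that something is new, unique, unknown or untested is made for them only; others in the source may bear on it.

Compound 1, `ClCc1ccc(Cn2cnc3c(Cl)ncnc32)cc1`: 18200 nM
Compound 2, `ClCc1ccccc1Cn1cnc2c(Cl)nc(Cl)nc21`: 4670 nM

In a functional assay on A549 cells (Homo sapiens) for cytotoxicity, read by sulforhodamine B assay, with a stated time of 48 h (a higher number here means a weaker inhibitor of growth, a lower number a stronger inhibitor of growth), compound 2 gives 4670 nM, the lowest of the two numbers, while compound 1 gives 18200 nM, a gap beyond the scatter. Compound 3, `ClCc1ccccc1Cn1cnc2c(Cl)ncnc21`, is not yet measured. Compared with compound 2 it carries hydrogen in place of chloro on an aromatic carbon, a hydrogen in place of chloro on an aromatic carbon between two ring nitrogen atoms. Among the measured compounds shown here, no measured pair shows this single change on its own: compound 1 and compound 2 differ in two places. The direction is uncertain, and the step of a 1.9-fold higher number from compound 2 to compound 3 (0.28 log units; within the scatter) is expected to stay modest. Compound 3 is estimated at 9000 nM, between 3000 nM and 27000 nM.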

Compound 3, concentration for total growth inhibition: 25700 nM
Beside the measured number, compound 3's estimate is 2.9-fold (0.46 log units) below it; measured number inside the range.
By their numbers in this assay, from the lowest: compound 2; then compounds 1 and 3 (each within the scatter of the next).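

Replacing the chloro on the aromatic carbon between two ring nitrogen atoms with hydrogen gives, in this assay, a 5.5-fold higher number from compound 2 to compound 3 (0.74 log units; beyond the scatter). Among the compounds shown here, this is the first reading of that single change, and it shows that in this pair the chloro goes with the stronger growth inhibition. Nothing available bears on why the number moves.

Going by these compounds, whether an amine or a methoxy group on this carbon would match the chloro or the hydrogen remains open. So does whether the chloro would shift the number of compound 1 in the same way.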